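The compounds below may be only part of what the source reports. "The series", "measured", "known", "first", "only" and "open" are said of these compounds alone.

In a functional assay on NCI-H460 cells (Homo sapiens) for cytotoxicity, read by MTT assay, with a stated time of 72 h (a lower number here means a stronger inhibitor, a higher number a weaker inhibitor), compound 1 `CCCN1C/C(=C\c2ccc(OC)c(OC)c2)C(=O)/C(=C/c2ccc(OC)c(OC)c2)C1` gives 4100 nM and compound 2 `CCN1C/C(=C\c2cc(OC)c(OC)c(OC)c2)C(=O)/C(=C/c2cc(OC)c(OC)c(OC)c2)C1` gives 4900 nM, so the two numbers lie within the usual scatter of each other. Compound 3 `CCN1C/C(=C\c2ccc(OC)c(OC)c2)C(=O)/C(=C/c2ccc(OC)c(OC)c2)C1` differs from compound 1 in one place: hydrogen in place of methyl on a saturated chain carbon, two bonds along the chain from an amine nitrogen in a ring. This puts hydrogen in place of methyl on a saturated chain carbon, two bonds along the chain from an amine nitrogen in a ring, so propyl becomes ethyl. Within the data shown here, no measured pair shows this change alone, so the expected step of a 1.0-fold higher number from compound 1 to compound 3 (0.02 log units; within the scatter) in this assay stays within the scatter, in no particular direction. The estimated value for compound 3 is 4300 nM, with an expected range of 1900 nM to 9500 nM.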

Compound 3, half-maximal inhibitory concentration: 3600 nM
Beside the measured number, compound 3's estimate is 1.2-fold (0.08 log units) above it, and the stated range covers the measured number.
By their numbers in this assay, from the lowest: compounds 3, 1 and 2 (each within the scatter of the next).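

Among these compounds, this pair gives the first direct reading of this position. Compounds 1 and 3 differ only at the end of the chain. In this assay, propyl becoming ethyl gives a 1.1-fold lower number from compound 1 to compound 3 (0.06 log units; within the scatter), so this methyl can be removed without a change that can be told from the scatter. No supporting evidence on this result is at hand. From the compounds shown here alone, whether a longer chain such as butyl, or a chain ending in an amine or a carboxylic acid, would behave the same stays open. So does whether this change would read alike on the core of compound 2.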